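Series notes: uracil sulfonamide triazoles, cytotoxicity on liver cells

The source may hold more compounds than are shown below. What is called first, only, known or untested is meant among the compounds shown, and "the series" means these compounds.

Measured so far:
compound 1, `O=c1[nH]cc(S(=O)(=O)Nc2ccccc2-c2cn(-c3ccc(F)cc3)nn2)c(=O)[nH]1`: "not toxic" (no number reported)
compound 2, `O=c1[nH]cc(S(=O)(=O)Nc2cccc(-c3cn(-c4ccccc4)nn3)c2)c(=O)[nH]1`: > 100000 nM
compound 3, `Cc1ccccc1-n1cc(-c2ccc(NS(=O)(=O)c3c[nH]c(=O)[nH]c3=O)cc2)nn1`: "not toxic" (no number reported)

In an ADME assay on L02 cells (Homo sapiens) for cytotoxicity, read by MTT assay, with a stated time of 24 h (on this read-out lower numbers stand for higher toxicity in this test and higher numbers for lower toxicity in this test), compound 1 is recorded only as "not toxic" (no number reported), without a number. Compound 2 reaches a limit of this assay, > 100000 nM, which is not a number but the edge of what was measured. Compound 3 likewise carries no single number in this assay, its entry reading "not toxic" (no number reported). Of the three values shown, one is the limit of > 100000 nM in this assay, at which 1 of the 3 values shown sits, and one is a wordless entry, so compound 3 stands among entries that all point the same way, toward low toxicity.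

The next compound, compound 4, is `O=c1[nH]cc(S(=O)(=O)Nc2ccc(-c3cn(-c4cccc(F)c4)nn3)cc2)c(=O)[nH]1`. It differs from compound 3 by 3-fluorophenyl in place of 2-methylphenyl on an aromatic nitrogen. For the measured compounds named here, no measured pair in this set changes at this position, so there is no step to lean on. Given that compound 2 sits at > 100000 nM and compounds 1 and 3 are both recorded as not toxic, no shift beyond the scatter is expected in either direction. Compound 4 is expected to give about 150000 nM, in the range 50000 nM to 500000 nM, most likely reported as a limit rather than a number.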

Compound 4, half-maximal cytotoxic concentration: "not toxic" (no number reported)
The entry for compound 4 holds no number; no gap can be computed for the estimate.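

Compound 3 and compound 4 are both recorded in this assay as not toxic, without a number, so no step can be read between them. The compounds shown leave open whether 3-fluorophenyl and 2-methylphenyl on the aromatic nitrogen differ in cytotoxicity at all.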